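From phenyl to 4-methoxyphenyl on compound 3

This account rests on a few compounds, and the source may have more. Where it says the series, first, only, none or still open, it means among the compounds named here.

In a functional assay on KB cells (Homo sapiens) for inhibition, read by sulforhodamine B assay (a lower number here means a stronger inhibitor of growth, a higher number a weaker inhibitor of growth), compound 1 `c1ccc(-c2ccc(-c3ccc(-c4nc5ccccc5[nH]4)cc3)cc2)cc1` gives 39700 nM and compound 2 `Oc1ccc(-c2ccc(-c3ccc(-c4nc5ccccc5[nH]4)cc3)cc2)cc1` gives 41000 nM as its result. Compound 3 `Oc1cccc2[nH]c(-c3ccc(-c4ccc(-c5ccccc5)cc4)cc3)nc12` gives 4010 nM as the lowest of the three numbers, beyond the scatter from both of the others.

Compound 4 `COc1ccc(-c2ccc(-c3ccc(-c4nc5c(O)cccc5[nH]4)cc3)cc2)cc1` is compound 3 with a single change methoxy in place of hydrogen on an aromatic carbon that puts methoxy in place of hydrogen on an aromatic carbon, so that phenyl becomes 4-methoxyphenyl.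

For the measured compounds named here, two measured steps bear on this. Hydroxy in place of hydrogen on that same phenyl gave a 1.0-fold higher number from compound 1 to compound 2 (0.01 log units; within the scatter) and so made no measurable difference. Hydroxy on the core instead gave a 9.9-fold lower number from compound 1 to compound 3 (1.00 log units; beyond the scatter) as a modest step, and compound 4 keeps that hydroxy. No methoxy has been measured yet, so a single hydroxy step is thin guidance. Even so, no step beyond the scatter is expected in this assay from the new group. The estimated change is a 1.1-fold higher number from compound 3 to compound 4 (0.05 log units; within the scatter) for this one group. Compound 4 is estimated at 4500 nM with an expected range of 1500 nM to 13000 nM in this test.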

Compound 4, concentration for 50% growth inhibition: 4900 nM
Beside the measured number, compound 4's estimate is 1.1-fold (0.04 log units) below it; the range from low to high includes it.
By their numbers in this assay, from the lowest: compounds 3 and 4 (each within the scatter of the next); then compounds 1 and 2 (each within the scatter of the next).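

In this assay, turning phenyl into 4-methoxyphenyl gives a 1.2-fold higher number from compound 3 to compound 4 (0.09 log units; within the scatter), so this change leaves the number where it was even with the hydroxy on the core present. Earlier, this ring position had been probed only with hydroxy, on a compound lacking the core hydroxy; it now also accepts methoxy, a group of 2 heavy atoms, without a step beyond the scatter. No measurement offered here explains why the number holds steady at this position.

Still open, from the compounds shown here alone, is whether an amine, a carboxylic acid or a chain longer than methoxy at this position would shift the number beyond the scatter. Also open, going by these compounds, is how hydroxy at this position would read on a compound that keeps the core hydroxy.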